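Notes on the thioether substituent series in gastric cancer cell assay

The source may report more compounds than this note shows. Statements on the series, on what has been measured and on what is new or still open speak of the compounds shown alone.

Three compounds share one core and differ only in the group carried on a saturated chain carbon bound to a sulfur. Compound 1 `CCCSc1nc2nc(C)cc(N3CC[C@@H](C)[C@@H](N(C)c4ncnc5[nH]ccc45)C3)n2n1` gives 51200 nM in a functional assay on BGC-823 cells (Homo sapiens) for inhibition, read by MTT assay, with a stated time of 72 h; a higher number here means a weaker inhibitor, a lower number a stronger inhibitor. Compound 2 `Cc1cc(N2CC[C@@H](C)[C@@H](N(C)c3ncnc4[nH]ccc34)C2)n2nc(SCC3CC3)nc2n1` gives 36500 nM in this assay, and compound 3 `Cc1cc(N2CC[C@@H](C)[C@@H](N(C)c3ncnc4[nH]ccc34)C2)n2nc(SCc3ccccc3Br)nc2n1` gives 81100 nM in this assay. Compound 2 has the lowest number of the three: the step of a 1.4-fold lower number from compound 1 to compound 2 (0.15 log units; within the scatter) is within the scatter, while the step of a 2.2-fold higher number from compound 2 to compound 3 (0.35 log units; beyond the scatter) is a modest one beyond the scatter. The step of a 1.6-fold higher number from compound 1 to compound 3 (0.20 log units; within the scatter) is within the scatter.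

Compound 4 `Cc1cc(N2CC[C@@H](C)[C@@H](N(C)c3ncnc4[nH]ccc34)C2)n2nc(SCc3ccc([N+](=O)[O-])cc3)nc2n1` is not yet measured. It differs from compound 2 by 4-nitrophenyl in place of cyclopropyl on a saturated chain carbon bound to a sulfur. The most informative measured step is a 2.2-fold higher number from compound 2 to compound 3 (0.35 log units; beyond the scatter), where another aromatic ring took the place of the cyclopropyl at the same position and the number rose modestly. Going by the values given here, a comparable aromatic replacement here is therefore expected to move the number in the same direction, by a modest amount, with no precedent for a nitro-bearing ring.

Compound 4 is estimated at 70000 nM in this assay, within a range of 35000 nM to 140000 nM. The expected step is a 1.9-fold higher number from compound 2 to compound 4 (0.28 log units; within the scatter).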

Compound 4, half-maximal inhibitory concentration: 59600 nM
Compound 4: middle estimate off by 1.2-fold (0.07 log units), on the high side; the range from low to high includes it.
By their numbers in this assay, from the lowest: compounds 2, 1, 4 and 3 (each within the scatter of the next, the first and the last beyond it).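

In this assay the 4-nitrophenyl group does not separate from any other member of the series: all three new steps lie within the scatter (a 1.6-fold higher number from compound 2 to compound 4 (0.21 log units; within the scatter); a 1.4-fold lower number from compound 3 to compound 4 (0.13 log units; within the scatter); a 1.2-fold higher number from compound 1 to compound 4 (0.07 log units; within the scatter)). Going by these compounds alone, the only step beyond the scatter among the four compounds therefore remains the modest one (a 2.2-fold higher number from compound 2 to compound 3 (0.35 log units; beyond the scatter)), so placing an aromatic ring in place of cyclopropyl on a saturated chain carbon bound to a sulfur does not give a step beyond the scatter in every case, with compound 4 as the case that goes against it. Exchanging the 3 heavy atoms of cyclopropyl for the 9 of 4-nitrophenyl, with 2 hydrogen-bond acceptors entering, thus leaves the number within the scatter of compound 2.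

Nothing at hand gives a reason for these values.

Still open, going by these compounds, is whether any group at this position can bring the number well away from this narrow band, for example a benzyl ring bearing an amine or a carboxylic acid, or a longer chain such as octyl.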